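Methoxy to ethoxy on the shared core

This account rests on a few compounds, and the source may have more. Where it says the series, first, only, none or still open, it means among the compounds named here.

Measured compounds:
Compound 1, `Cc1nc2c(OCc3ccccc3)cccn2c1CO`, in a functional assay on the whole organism (stomach) for inhibition, with Canis familiaris (Canis lupus familiaris) as the target, at a dose of 5 mg/kg by the intravenous route (a lower number here means a weaker effect, a higher number a stronger effect of the compound at the dose given), gives 80%
Compound 2, `COCc1c(C)nc2c(OCc3ccccc3)cccn12`, in this assay gives 29%

Compound 2 stands lowest of the two numbers, separated from compound 1 by the step of a number 51 percentage points lower from compound 1 to compound 2 (beyond the scatter). Compound 3, `CCOCc1c(C)nc2c(OCc3ccccc3)cccn12`, differs from compound 2 by methyl in place of hydrogen on a saturated chain carbon bound to an oxygen on a saturated carbon. Within the data shown here, only the step of a number 51 percentage points lower from compound 1 to compound 2 (beyond the scatter) bears on this change; it shows that adding carbon at this oxygen lowered the read-out strongly, but the new methyl sits one bond further out, so that step is an imperfect guide. A small further lowering, a number 7 percentage points lower from compound 2 to compound 3 (within the scatter), is expected, likely within the scatter. Compound 3 is estimated at 22%, in the range 5% to 45%.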

Compound 3, a percentage reported as inhibition, in the whole organism at one dose (the size of the read-out at that dose, not a potency): 35%
Estimate against measurement, compound 3: 13 percentage points below; the range from low to high includes it.
By their numbers in this assay, from the lowest: compounds 2 and 3 (each within the scatter of the next); then compound 1.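

Going from methoxy to ethoxy gives a number 6 percentage points higher from compound 2 to compound 3 (within the scatter), so in this assay the methyl and ethyl ethers cannot be told apart. Ethyl in place of the hydrogen on the oxygen gives a number 45 percentage points lower from compound 1 to compound 3 (beyond the scatter), so among these three compounds the large difference separates the free alcohol of compound 1 from both ethers, whichever of the two groups is on the oxygen.

From the compounds shown here alone, whether a longer chain on this oxygen, or an amine in place of it, would stay near compound 2 and compound 3 remains open. No measured evidence speaks to what lies behind these differences.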